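Trimming a furan-bearing side chain to a methyl

The source may hold more compounds than are shown below. What is called first, only, known or untested is meant among the compounds shown, and "the series" means these compounds.

Measured compounds:
compound 1 `CC1(C)CCC[C@]2(C)[C@@H](/C=C/c3ccoc3)C(C=O)=C(O)C(=O)[C@@H]12`, 37900 nM
compound 2 `CC1(C)CCC[C@]2(C)[C@@H](/C=C/c3ccoc3)C(CO)=CC(=O)[C@@H]12`, 51200 nM
compound 3 `C=C1CC[C@H]2C(C)(C)CCC[C@]2(C)[C@H]1/C=C/c1ccoc1`, 53300 nM

All three compounds were tested in a functional assay on A549 cells (Homo sapiens) for cytotoxicity, read by MTT assay; on this read-out higher numbers stand for weaker inhibition and lower numbers for stronger inhibition. Compound 3 gives 53300 nM, the largest of the three numbers, yet its gaps to compound 2 and to compound 1 both fall within the usual scatter of repeated measurements, so the three compounds cannot be told apart on this read-out.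

Compound 4 `C=C1CC[C@H]2C(C)(C)CCC[C@]2(C)[C@H]1C` differs from compound 3 in one place: methyl in place of 2-(furan-3-yl)ethenyl on a saturated ring carbon. Within the data shown here, no measured pair shows the effect of this exact change, so the expectation rests only on the three values shown, which cluster closely in this assay.

Without a measured pair to guide it, the step is expected to be modest; from compound 3 to compound 4 the estimate amounts to a 1.6-fold higher number from compound 3 to compound 4 (0.20 log units; within the scatter), toward a weaker effect. In this assay compound 4 is therefore expected to give about 85000 nM, with a range from 30000 nM to 250000 nM.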

Compound 4, half-maximal inhibitory concentration: 61300 nM
Compound 4: middle estimate off by 1.4-fold (0.14 log units), on the high side; the measured number falls inside the stated range.
By their numbers in this assay, from the lowest: compounds 1, 2, 3 and 4 (each within the scatter of the next).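

In this assay, the change gives a 1.2-fold higher number from compound 3 to compound 4 (0.06 log units; within the scatter), so this step stays within the scatter. The earlier compounds shown here all keep the 2-(furan-3-yl)ethenyl group, so they could not show what happens without it. Here, that group, with its five-membered aromatic ring and its double bond, gives way to a methyl on the saturated ring carbon with no change that this read-out can distinguish. No available evidence bears on why this swap leaves the number within the scatter.

From the compounds shown here alone, it remains open whether an amine, a carboxylic acid or a longer chain on this same carbon would produce a step beyond the scatter. Going by these compounds, it is also open whether methyl in place of the 2-(furan-3-yl)ethenyl group would behave the same way on the cores of compound 1 and compound 2.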